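Amide Variation on a Shared Naphthyl Core: Efficacy Notes

This account rests on a few compounds, and the source may have more. Where it says the series, first, only, none or still open, it means among the compounds named here.

The three measured compounds share one core and differ only in the group on the carbonyl carbon of the amide. Compound 1 `CCC(=O)Nc1c(C(O)(C(F)(F)F)C(F)(F)F)ccc2ccccc12` gives 96% in a functional assay (Sus scrofa) with sulfonylurea receptors; K-ATP channels (Homo sapiens) as the target; a higher number here means a larger maximal response, a lower number a smaller maximal response. Compound 2 `C/C=C/C(=O)Nc1c(C(O)(C(F)(F)F)C(F)(F)F)ccc2ccccc12` gives 96% in this assay, and compound 3 `COCC(=O)Nc1c(C(O)(C(F)(F)F)C(F)(F)F)ccc2ccccc12` gives 93%. The steps of no change at the digits printed from compound 1 to compound 2 (within the scatter) and a number 3 percentage points lower from compound 1 to compound 3 (within the scatter) and a number 3 percentage points lower from compound 2 to compound 3 (within the scatter) are all within the scatter, so compound 3 stands in the same band as compound 1 and compound 2, with no separation that the measurements can resolve.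

Compound 4 `O=C(Nc1c(C(O)(C(F)(F)F)C(F)(F)F)ccc2ccccc12)c1cccc(Cl)c1` is the next member. The change from compound 3 is 3-chlorophenyl in place of methoxymethyl on a carbonyl carbon. Within the data shown here, no measured step exchanges a saturated chain for an aromatic ring on the carbonyl carbon; the steps that bear on it are a number 3 percentage points lower from compound 2 to compound 3 (within the scatter) and a number 3 percentage points lower from compound 1 to compound 3 (within the scatter), which show the maximal response unmoved by smaller replacements at this position. On that basis the expected step of a number 3 percentage points lower from compound 3 to compound 4 (within the scatter) is small, possibly toward a slightly smaller maximal response, but not clearly beyond the scatter. Compound 4 is therefore estimated at 90% in this assay, within a range of 70% to 102%, the range being widened because the replacement is larger than any measured so far.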

Compound 4, largest response reached (reported as efficacy), in percent of the reference or control that the assay uses: 84%
Compound 4: the middle estimate sits 6 percentage points above what was measured, and the stated range covers the measured number.
By their numbers in this assay, from the lowest: compounds 4, 3, 1 and 2 (each within the scatter of the next, the first and the last beyond it).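

In this assay, among these compounds, the 3-chlorophenyl group on the carbonyl carbon gives the first steps that lie beyond the scatter, with a number 12 percentage points lower from compound 1 to compound 4 (beyond the scatter) and a number 12 percentage points lower from compound 2 to compound 4 (beyond the scatter) as the two modest steps, while a number 9 percentage points lower from compound 3 to compound 4 (within the scatter) stays within it. The maximal response is thus not wholly indifferent to the group at this position: ethyl, prop-1-en-1-yl and methoxymethyl showed no separation that could be resolved, whereas the entering six-membered aromatic ring with its chlorine separates compound 4 from compound 1 and from compound 2, though not from compound 3. Nothing available explains this separation in maximal response.

The change brings in the ring and the chlorine together, so these compounds cannot show which of the two goes with the lower number, a question that an unsubstituted phenyl group on the carbonyl carbon would address. Also open, as far as these compounds go, is how the response behaves with a longer chain, an amine or a carboxylic acid at this position, or with the chlorine placed elsewhere on the ring.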